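The source may hold more compounds than are shown below. What is called first, only, known or untested is meant among the compounds shown, and "the series" means these compounds.

Series notes. Within the data shown here, in a toxicity assay on Huh-7.5 cells (Homo sapiens) for inhibition, read by MTT assay, with a stated time of 96 h (on this read-out lower numbers stand for higher toxicity in this test and higher numbers for lower toxicity in this test), compound 1 `CN1CCN(Cc2ccc(NC(=O)c3ccc(OCCCCl)c(N)c3)cc2C(F)(F)F)CC1` gives 12900 nM, the lower of the two numbers so far. Compound 2 `CC(C)Oc1ccc(C(=O)Nc2ccc(N(C)C)cc2)cc1[N+](=O)[O-]` gives 50000 nM in this assay, a higher number, and the gap between the two lies beyond the scatter. Compound 3 `CN1CCN(Cc2ccc(NC(=O)c3ccc(OCCCCl)c(F)c3)cc2C(F)(F)F)CC1` has not yet been measured. It differs from compound 1 in one place: fluoro in place of amino on an aromatic carbon. Among the measured compounds shown here, no measured pair shows this change, so the step from compound 1 to compound 3 in this assay is expected to stay within the scatter, as a 1.1-fold lower number from compound 1 to compound 3 (0.03 log units; within the scatter). For compound 3 a value of 12000 nM is estimated, within 5000 nM to 30000 nM.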

Compound 3, half-maximal cytotoxic concentration: 8800 nM
The estimate for compound 3 lay 1.4-fold (0.13 log units) above the measured number, and the stated range covers the measured number.
By their numbers in this assay, from the lowest: compounds 3 and 1 (each within the scatter of the next); then compound 2.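

In this assay, among these compounds, the change of amino to fluoro gives a 1.5-fold lower number from compound 1 to compound 3 (0.17 log units; within the scatter) in the first one-place comparison. At this aromatic carbon, ortho to the 3-chloropropoxy group, the hydrogen-bond donor and acceptor counted for amino can therefore go without a shift beyond the scatter. No measurement of any other property bears on this result. On these data alone, it remains open whether a hydroxyl or methoxy group on this carbon would also stay within the scatter. As far as these compounds go, the outcome of a longer chain in place of the 3-chloropropoxy group is equally open.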